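The source may hold more compounds than are shown below. What is called first, only, known or untested is meant among the compounds shown, and "the series" means these compounds.

Compound 1 `COc1ccc(-c2cc(=O)c3c(OC)cc(OC)cc3[nH]2)cc1` is the starting point. In a functional assay on SEM cells (Homo sapiens) for antiproliferative activity, with a stated time of 72 h (a lower number here means that less compound is needed, a higher number that more compound is needed for the effect), compound 1 reaches only (the limit of > 31100 nM in this assay, at which 1 of the 3 values shown sits), reported as > 31100 nM, so no number is known for it. Compound 3 `COC(=O)c1cc(=O)c2cc(N)ccc2[nH]1` likewise reaches only (the limit of > 33700 nM in this assay, at which 1 of the 3 values shown sits), reported as > 33700 nM. Within the data shown here, compound 2 `COC(=O)c1cc(=O)c2c(OC)cc(OC)cc2n1S(=O)(=O)c1ccc(C)cc1` is the one compound with a measured number, and in this assay compound 2 gives 5800 nM. Among the three, compound 1 thus stands at a limit alongside compound 3, while compound 2 alone sits inside the measurable range.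

Compound 4 `COc1ccc(-c2cc(=O)c3c(OC)cc(OC)cc3n2S(=O)(=O)c2ccc(C#N)cc2)cc1` differs from compound 1 in one place: (4-cyanophenyl)sulfonyl in place of hydrogen on an aromatic nitrogen. Among the measured compounds shown here, no measured pair shares exactly this change. For the measured compounds named here, compound 2 also carries a sulfonyl substituent on its ring nitrogen and gives 5800 nM, which is the only guide available. On that basis the step is expected to move toward lower numbers, beyond the usual scatter, and to amount to an at least 3.8-fold lower number from compound 1 to compound 4 (0.58 log units; beyond the scatter). Compound 4 is estimated at 8000 nM, with a likely range from 2500 nM to 25000 nM.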

Compound 4, half-maximal effective concentration: 1300 nM
Compound 4: middle estimate off by 6.2-fold (0.79 log units), on the high side; measured number below the stated range.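

Putting (4-cyanophenyl)sulfonyl in place of hydrogen on the aromatic nitrogen gives an at least 23-fold lower number from compound 1 to compound 4 (1.37 log units; beyond the scatter) in this assay. Among these compounds, the earlier compounds included no pair differing only at this nitrogen, so this is the first direct reading of a change there, and it shows that this position can tolerate a large substituent while the number falls well beyond the scatter. The step is only a minimum, as its starting point is not a true number and compound 1 stands at a limit: the limit of > 31100 nM in this assay, at which 1 of the 4 values shown sits.

The compounds shown do not separate the part played by the sulfonyl link from that of the 4-cyanophenyl ring. They also leave open how a plain methyl, an acetyl or a benzyl group on the same nitrogen would compare with hydrogen.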